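A few compounds are considered here, and "the series" means these few. Any claim that something is new, unique, unknown or untested is made for them only; others in the source may bear on it.

Compound 3 `COc1ccc2c(=O)c(/C=C/C(=O)NCc3ccccc3F)coc2c1` sits at the limit of a functional assay on HeLa cells (Homo sapiens) for inhibition, read by MTT assay, with a stated time of 48 h (on this read-out higher numbers stand for weaker inhibition and lower numbers for stronger inhibition), where compound 3 gives > 100000 nM. Compound 1 `COc1ccc(CNC(=O)/C=C/c2coc3cc(O)ccc3c2=O)cc1` also reaches a limit in this assay, with compound 1 giving > 100000 nM. Among the compounds with values here, compound 2 `COc1ccc2c(=O)c(/C=C/C(=O)Nc3ccccc3Cl)coc2c1` is the only member with a number, as compound 2 gives 22400 nM in this assay. Within the data shown here, the one measured step, an at least 4.4-fold higher number from compound 2 to compound 3 (0.64 log units; beyond the scatter), runs toward the limit (the limit of > 100000 nM in this assay, at which 2 of the 3 values shown sit). Compound 4 `COc1ccc(CNC(=O)/C=C/c2coc3cc(OC)ccc3c2=O)cc1` differs from compound 3 by 4-methoxyphenyl in place of 2-fluorophenyl on a saturated chain carbon bound to an amide-type nitrogen. Among the measured compounds shown here, no measured step bears directly on this change; compound 1, which carries the same 4-methoxybenzyl on a different core, sits at the limit as well. Compound 4 is therefore expected to stay near the limit, a step that the limit leaves unreadable from compound 3 to compound 4, with an estimate of 150000 nM within 30000 nM to 1000000 nM.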

Compound 4, half-maximal inhibitory concentration: > 100000 nM
Compound 4: no number, only a limit (the forecaster's own chance of this, stated with the estimate: 75%); the middle value does not contradict the limit.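

Within the data shown here, replacing 2-chlorophenyl with 4-methoxybenzyl on the amide-type nitrogen gives an at least 4.4-fold higher number from compound 2 to compound 4 (0.64 log units; beyond the scatter) in this assay, so a second benzyl group on the shared core, after 2-fluorobenzyl, also lies clear of the one compound with a number. The steps to compound 4 from compound 3 and from compound 1 cannot be read, as both ends are limits. The value of compound 4 is a limit too, and all three benzyl amides, but not compound 2, end there: the limit of > 100000 nM in this assay, at which 3 of the 4 values shown sit.

The benzyl substituents therefore cannot be ranked against each other. Open, going by these compounds, is whether 2-chlorobenzyl on that nitrogen, or a carboxylic acid on the phenyl ring, would give a number rather than a limit in this assay.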